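The source may report more compounds than this note shows. Statements on the series, on what has been measured and on what is new or still open speak of the compounds shown alone.

compound 1 `O=c1cc(-c2ccc(Cl)c([N+](=O)[O-])c2)oc2ccccc12`: 40900 nM
compound 2 `COc1cc(OC)cc(-c2cc(=O)c3ccccc3o2)c1`: < 100 nM, a limit of the assay rather than a number

Both were tested in a functional assay on MCF7 cells (Homo sapiens) for cytotoxicity, read by sulforhodamine B assay, with a stated time of 48 h; a higher number here means a weaker inhibitor of growth, a lower number a stronger inhibitor of growth. Compound 1 gives the only number shown, 40900 nM, so it stands as a weak inhibitor of growth. The remaining value, from compound 2, is the limit of < 100 nM in this assay, at which 1 of the 2 values shown sits. Compound 3 `O=c1cc(-c2cccc([N+](=O)[O-])c2)oc2ccccc12` has not yet been measured. It differs from compound 1 in one place: hydrogen in place of chloro on an aromatic carbon. For the measured compounds named here, no step between two measured compounds shows what hydrogen in place of chloro on an aromatic carbon does here, so the step of a 1.1-fold higher number from compound 1 to compound 3 (0.04 log units; within the scatter) is expected to stay within the usual scatter, in no clear direction. Compound 3 is therefore estimated at 45000 nM, with a likely range from 15000 nM to 135000 nM.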

Compound 3, concentration for 50% growth inhibition: 31000 nM
Compound 3: the middle estimate sits 1.5-fold (0.16 log units) above what was measured, and the stated range covers the measured number.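

Hydrogen in place of chloro, ortho to a nitro group, gives a 1.3-fold lower number from compound 1 to compound 3 (0.12 log units; within the scatter) in this assay and leaves the two compounds indistinguishable. For the compounds shown here, at this place on the ring, then, the chloro group can go without a clear change in growth inhibition, something no earlier pair of compounds could show. Nothing measured here explains why this step is so small.

On these data alone, whether the nitro group itself matters remains open. So does whether a larger change at the chloro position, such as an amine or a carboxylic acid, would move the number beyond the scatter.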